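Series notes on compounds 1 to 4

This account rests on a few compounds, and the source may have more. Where it says the series, first, only, none or still open, it means among the compounds named here.

Measured compounds:
compound 1 `O=C1/C(=C\c2cc3ccccc3nc2Cl)c2ccccc2N1c1c(Cl)cccc1Cl` — a functional assay on HuTu80 cells (Homo sapiens) for cytotoxicity, read by MTT assay, with a stated time of 72 h; a lower number here means that less compound is needed, a higher number that more compound is needed for the effect: "not determined" (no result reported)
compound 2 `Cc1ccc2nc(Cl)c(/C=C3\C(=O)N(c4c(Cl)cccc4Cl)c4ccccc43)cc2c1C` — in this assay compound 2 gives < 1 ug/mL, a limit of the assay
compound 3 `CN(C)c1ccc(/C=C2\C(=O)N(c3c(Cl)cccc3Cl)c3ccccc32)cc1` — in this assay compound 3 gives < 1 ug/mL, a limit of the assay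

Going by the values given here, compound 3 thus stands only at the limit of < 1 ug/mL in this assay, at which 2 of the 3 values shown sit, and not at a number, and no step between measured compounds can be read from the set. Compound 4 `O=C1/C(=C\c2ccc(Cl)cc2)c2ccccc2N1c1c(Cl)cccc1Cl` differs from compound 3 by chloro in place of dimethylamino on an aromatic carbon. Among the compounds with values here, with no measured step to lean on, the step of a number no lower from compound 3 to compound 4 (the limit leaves the size open) is expected to be small, within the scatter, in no clear direction. Compound 4 is expected to give 1 ug/mL, with a range from 0.3 ug/mL to 4 ug/mL, and it may well again be reported only as a limit.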

Compound 4, concentration for half-maximal effect: 6 ug/mL
Beside the measured number, compound 4's estimate is 6.0-fold (0.78 log units) below it; the whole stated range lies below it.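

In this assay, going by these compounds alone, chloro in place of dimethylamino on an aromatic carbon gives the first readable step, an at least 6.0-fold higher number from compound 3 to compound 4 (0.77 log units; beyond the scatter), so this position responds to the change. Compound 3 gives < 1 ug/mL, which is a limit of the assay. The step is therefore only a bound, and its full size stays open: the limit of < 1 ug/mL in this assay, at which 2 of the 4 values shown sit.

The compounds shown leave open whether the step belongs to the loss of dimethylamino or to the arrival of chloro. From the compounds shown here alone, how a primary amine or a carboxylic acid would read at this place also remains open.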